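Swapping the Aminopiperidine for a Methylpiperazine on a Fused Core

This account rests on a few compounds, and the source may have more. Where it says the series, first, only, none or still open, it means among the compounds named here.

Going by the values given here, compound 2 `CN(Cc1cn2c(N3CCC(N)CC3)cccc2n1)[C@H]1CCCc2cccnc21` stands alone with a number in an ADME assay on HOS cells (Homo sapiens) for cytotoxicity; a lower number here means that less compound is tolerated, a higher number that more compound is tolerated: compound 2 gives 6300 nM, the only value that is a number rather than a limit. Compound 1 `CN1CCN(c2cccn3cc(CN(C)[C@H]4CCCc5cccnc54)nc23)CC1` stops at a limit of the assay, > 5000 nM. That is the limit of > 5000 nM in this assay, at which 1 of the 2 values shown sits.

Compound 3 `CN1CCN(c2cccc3nc(CN(C)[C@H]4CCCc5cccnc54)cn23)CC1` keeps every atom of compound 2 but joins them differently: 4-methylpiperazin-1-yl in place of 4-aminopiperidin-1-yl on an aromatic carbon. Among the compounds with values here, no pair of measured compounds differs in a single place, so no measured step is available for comparison. With both measured values sitting high, the expected 1.1-fold higher number from compound 2 to compound 3 (0.05 log units; within the scatter) is small, within the scatter rather than beyond it, and the direction cannot be read from the two values shown. Compound 3 is therefore estimated to give 7000 nM in this assay, with a plausible span from 3000 nM to 20000 nM, and the assay may again report only a limit.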

Compound 3, half-maximal cytotoxic concentration: 4500 nM
Compound 3: middle estimate off by 1.6-fold (0.19 log units), on the high side; low and high end bracket the measured number.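

In this assay the exchange gives a 1.4-fold lower number from compound 2 to compound 3 (0.15 log units; within the scatter) and so now has a measured size. On this aromatic carbon, next to the ring nitrogen, the two values cannot be told apart, even though 4-methylpiperazin-1-yl has 0 hydrogen-bond donors against 1 for 4-aminopiperidin-1-yl and its ring has 2 hetero atoms rather than 1. Compound 1 remains a limit of the assay and not a number, which keeps it out of any step: the limit of > 5000 nM in this assay, at which 1 of the 3 values shown sits.

From the compounds shown here alone, whether a morpholine or a plain dimethylamino group on the same carbon would also stay within the scatter in this assay remains open. So does whether this exchange would give a similar result elsewhere on the core, since only one such pair is shown.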